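Cyano for methyl on the fused aromatic ring

The compounds below may be only part of what the source reports. "The series", "measured", "known", "first", "only" and "open" are said of these compounds alone.

The series shares one core carrying a fluoro group and a fused ring. Compound 1 `Cc1cc(F)c(CNc2ncc(-c3cccnc3C)c3nncn23)c2c1OCC2` gives "not determined" (no result reported) in an assay on isolated protein for binding affinity to Polycomb protein EED (Homo sapiens), read by surface plasmon resonance; a lower number here means tighter binding, a higher number weaker binding: no result was reported for it. Compound 2 `Cc1ncccc1-c1cnc(NCc2c(F)cc(O)c3c2CCO3)n2cnnc12` likewise gives "not determined" (no result reported) in this assay. Going by the values given here, compound 3 `Cc1ncccc1-c1cnc(NCc2c(F)cc(F)c3c2CCO3)n2cnnc12` gives 1200 nM in this assay, the only number the series offers. Compound 4 `Cc1ncccc1-c1cnc(NCc2c(F)cc(C#N)c3c2CCO3)n2cnnc12` differs from compound 1 by cyano in place of methyl on an aromatic carbon. Among the compounds with values here, no step between two measured compounds is available to say how such a change behaves in this assay, so the step from compound 1 to compound 4 is expected to be modest, in either direction, and possibly within the usual scatter. Compound 4 is therefore estimated at 1500 nM, with a range of 400 nM to 6000 nM, anchored on compound 3 at 1200 nM.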

Compound 4, dissociation constant in the Polycomb protein EED assay: 15000 nM
Beside the measured number, compound 4's estimate is 10-fold (1.00 log units) below it; measured number above the stated range.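

Going by these compounds alone, in the Polycomb protein EED assay, the position para to a large group is sensitive to this change: cyano in place of fluoro gives a 13-fold higher number from compound 3 to compound 4 (1.10 log units; beyond the scatter), the first step that can be read, and it runs towards weaker binding. In a physicochemical assay for lipophilicity, using the shake flask method, in phosphate buffer, measured as octanol-water partition, at pH 7.4 (on this read-out lower numbers stand for lower lipophilicity and higher numbers for higher lipophilicity), compound 4 gives 2.2, whereas compound 1 gives "not determined" (no result reported), leaving no comparison there. Nothing shown accounts for the loss of binding.

Steps involving compound 1 or compound 2 cannot be read in the Polycomb protein EED assay. On these data alone, how an amine or a chloro group at this position would compare with the fluoro group of compound 3 remains open.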